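Chloro on the Fused Ring of Compound 1

The source may report more compounds than this note shows. Statements on the series, on what has been measured and on what is new or still open speak of the compounds shown alone.

Compound 1 `CCc1nc2ccccc2n1CCCCOc1ccccc1`, compound 2 `CCc1nc2ccccc2n1CCCCOc1ccc(C)cc1` and compound 3 `CCc1nc2ccccc2n1CCCCOc1ccc(C)c(Cl)c1` were measured in an ADME assay on Vero cells (Chlorocebus sabaeus) for cytotoxicity, read by luminescence, with a stated time of 2 days; on this read-out lower numbers stand for higher toxicity in this test and higher numbers for lower toxicity in this test. Compound 1 gives 21 uM, compound 2 gives 14 uM and compound 3 gives 14 uM. The change chloro in place of hydrogen on an aromatic carbon made the step of no change at the digits printed from compound 2 to compound 3 (within the scatter). Compound 4 `CCc1nc2ccc(Cl)cc2n1CCCCOc1ccccc1` carries the same kind of change relative to compound 1, (chloro in place of hydrogen on an aromatic carbon); the two cores differ by hydrogen in place of methyl on an aromatic carbon. The surroundings are not alike: in compound 3 the chloro sits ortho to a methyl group and meta to a large group, whereas in compound 4 it sits on a ring that is part of a fused or bridged system of two rings, meta to a fused ring and para to a fused ring. Because no change at the digits printed from compound 2 to compound 3 (within the scatter) stayed within the scatter, the step of a 1.2-fold lower number from compound 1 to compound 4 (0.07 log units; within the scatter) is expected to be small as well. Compound 4 is therefore estimated at 18 uM, with a likely range from 9 uM to 36 uM.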

Compound 4, half-maximal toxic concentration: 25 uM
Estimate against measurement, compound 4: 1.4-fold (0.14 log units) below; the range from low to high includes it.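

In this assay, chloro in place of hydrogen on an aromatic carbon gave a 1.2-fold higher number from compound 1 to compound 4 (0.08 log units; within the scatter). Set beside the earlier case, the change carried from one core to the other without a difference that can be told from the scatter: the same change on two cores in this assay, no change at the digits printed (within the scatter) from compound 2 to compound 3 and a 1.2-fold higher number (0.08 log units; within the scatter) from compound 1 to compound 4, 1.2-fold (0.08 log units) apart, within the scatter of two such steps. For the compounds shown here, this shows only that the step stayed small on these two cores, at the two places it occupies in compound 3 and compound 4; it does not show that chloro would stay as small on other cores or at other places.

The compounds shown leave open whether a bromo, an amine or a carboxylic acid in place of that chloro would give an equally small step. They also leave open whether chloro on a core with a longer chain would do the same.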